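A few compounds are considered here, and "the series" means these few. Any claim that something is new, unique, unknown or untested is made for them only; others in the source may bear on it.

Compound 1 `CC(C)Oc1cc(Oc2cnc(C(=O)N(C)C)nc2)cc(-c2nccc(=O)[nH]2)c1`: < 8 mL/min/kg (a limit)
Compound 2 `C[C@@H](CO)Oc1cc(Oc2cnc(C(=O)N(C)C)nc2)cc(-c2nccc(=O)[nH]2)c1`: < 8 mL/min/kg (a limit)

In an ADME assay on microsomes from liver (Homo sapiens) for metabolic stability (a higher number here means faster removal of the compound, a lower number slower removal), compound 1 gives < 8 mL/min/kg, which is a limit and not a number. Compound 2 gives < 8 mL/min/kg, which is also a limit. The whole picture so far is the limit of < 8 mL/min/kg in this assay, at which 2 of the 2 values shown sit, so compound 1 has no exact place on the scale.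

The next compound, compound 3 `Cc1cnc(-c2cc(Oc3cnc(C(=O)N(C)C)nc3)cc(OC(C)C)c2)[nH]c1=O`, differs from compound 1 in one place: methyl in place of hydrogen on an aromatic carbon. In words, this is methyl in place of hydrogen on an aromatic carbon, on a six-membered aromatic ring with 2 nitrogen.

Among the measured compounds shown here, only one measured step exists to compare it with: a step that the two limits leave unreadable from compound 1 to compound 2. That change is a hydroxy on a saturated chain carbon, not a methyl on this ring, and its size cannot be read. For the measured compounds named here, it therefore gives little guidance, and no measurement yet shows what a methyl does at this place. The expectation in this assay is no change beyond the usual scatter, with no favoured direction, and the expected step is a number no lower from compound 1 to compound 3 (the limit leaves the size open). For compound 3 the estimated clearance is 8 mL/min/kg, with an expected range from 5 mL/min/kg to 15 mL/min/kg.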

Compound 3, clearance: < 8 mL/min/kg
Compound 3: only a limit was reported; the forecaster's own chance of this, stated with the estimate: 60%; the middle value lies on the limit itself.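

Compound 3 also gives only a limit and not a number in this assay, so the step from compound 1 to compound 3 cannot be read, and all three compounds stay unresolved: the limit of < 8 mL/min/kg in this assay, at which 3 of the 3 values shown sit. The compounds shown leave open how far apart their true clearances lie, and whether the methyl or the hydroxy changes clearance at all.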